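A few compounds are considered here, and "the series" means these few. Any claim that something is new, unique, unknown or untested is made for them only; others in the source may bear on it.

Compound 1 `Nc1nc(-c2ccc(Cl)cc2)c(CC(=O)O)s1`; in an in vitro functional assay on HEK285-7 cells for antagonist activity at prostaglandin D2 receptor 2 (Homo sapiens), read by BRET and beta-arrestin recruitment (on this read-out higher numbers stand for weaker inhibition and lower numbers for stronger inhibition), compound 1 gives > 100000 nM, a limit of the assay rather than a number.
Compound 2 `O=C(O)Cc1sc(NCc2ccccc2)nc1-c1ccc(Cl)cc1`; in this assay compound 2 gives 2300 nM.

For the measured compounds named here, compound 2 holds the only number in this pair; the other value is the limit of > 100000 nM in this assay, at which 1 of the 2 values shown sits. Compound 3 `O=C(O)Cc1sc(NC(=O)c2ccccc2)nc1-c1ccc(Cl)cc1` differs from compound 2 by benzoyl in place of benzyl on a nitrogen on an aromatic ring. Going by the values given here, the single measured step, an at least 43-fold lower number from compound 1 to compound 2 (1.63 log units; beyond the scatter), concerns the same nitrogen but compares hydrogen with benzyl, not benzyl with benzoyl, so it bears on the present step only loosely. With a ring-bearing substituent kept on that nitrogen, compound 3 is expected to stay near compound 2, the step of a 1.7-fold higher number from compound 2 to compound 3 (0.24 log units; within the scatter) being the estimate. Compound 3 is estimated at 4000 nM, range 800 nM to 30000 nM.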

Compound 3, half-maximal inhibitory concentration: 870 nM
Estimate against measurement, compound 3: 4.6-fold (0.66 log units) above; low and high end bracket the measured number.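

On the nitrogen on an aromatic ring, the two ring-bearing groups are not interchangeable: benzoyl in place of benzyl gives a 2.6-fold lower number from compound 2 to compound 3 (0.42 log units; beyond the scatter), a modest move towards stronger inhibition. Benzoyl in place of hydrogen gives an at least 110-fold lower number from compound 1 to compound 3 (2.06 log units; beyond the scatter). That step is only a bound, since compound 1 stands at a limit and not at a number: the limit of > 100000 nM in this assay, at which 1 of the 3 values shown sits.

Whether the carbonyl alone accounts for the shift from benzyl to benzoyl stays open. So does how a longer chain such as phenylacetyl, or benzenesulfonyl, would read on this nitrogen.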